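The source may report more compounds than this note shows. Statements on the series, on what has been measured and on what is new or still open speak of the compounds shown alone.

Of the compounds shown here, two that share one core have so far been measured in a functional assay on B16-F10 cells (Mus musculus) for antiproliferative activity, read by MTT assay, with a stated time of 48 h; on this read-out higher numbers stand for weaker inhibition and lower numbers for stronger inhibition. Compound 1 `Cc1ncc([N+](=O)[O-])n1CC(=O)NS(=O)(=O)c1ccc(F)cc1` gives 0.35 ug/mL, and compound 2 `Cc1ncc([N+](=O)[O-])n1CC(=O)NS(=O)(=O)c1ccc(Br)cc1` gives 2.37 ug/mL. Compound 2 therefore holds the higher of the two numbers, and the step of a 6.8-fold higher number from compound 1 to compound 2 (0.83 log units; beyond the scatter) sets it clearly apart from compound 1. Compound 3 `Cc1ccc(S(=O)(=O)NC(=O)Cn2c([N+](=O)[O-])cnc2C)cc1` has not yet been measured; it differs from compound 2 by methyl in place of bromo on an aromatic carbon. Among the measured compounds shown here, only one measured step bears on this change, the exchange of one group at the same place seen in a 6.8-fold higher number from compound 1 to compound 2 (0.83 log units; beyond the scatter), which moved the number by a modest amount. That step shows that the number responds to what sits at this position, but it gives no direct guide for methyl. Compound 3 is therefore expected to fall near compound 2 or between compound 2 and compound 1, an estimated step of a 2.0-fold lower number from compound 2 to compound 3 (0.30 log units; within the scatter). The estimate for compound 3 in this assay is 1.2 ug/mL, with a range from 0.35 ug/mL to 4 ug/mL.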

Compound 3, half-maximal inhibitory concentration: 3.55 ug/mL
For compound 3 the middle estimate is 3.0-fold (0.47 log units) below the measured one; the measured number falls inside the stated range.
By their numbers in this assay, from the lowest: compound 1; then compounds 2 and 3 (each within the scatter of the next).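

In this assay, methyl in place of bromo gives a 1.5-fold higher number from compound 2 to compound 3 (0.18 log units; within the scatter), so compound 2 and compound 3 cannot be told apart, even though the entering group is a carbon and the leaving one a bromine. Measured against fluoro, the same methyl group gives a 10-fold higher number from compound 1 to compound 3 (1.01 log units; beyond the scatter), so a second group on this aromatic carbon now stands clearly apart from compound 1. Among these three compounds, the earlier gap between fluoro and bromo is therefore no longer a single contrast: compound 1 has the strongest inhibition, while compound 2 and compound 3 share one level.

Nothing available here explains why fluoro differs from the other two groups. From the compounds shown here alone, it also remains open whether chloro, methoxy, an amine or a carboxylic acid at this place would sit with compound 1 or with compound 2 and compound 3.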